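Bromophenyl Acid Replaces Methyl Ester on the Aniline Nitrogen

A few compounds are considered here, and "the series" means these few. Any claim that something is new, unique, unknown or untested is made for them only; others in the source may bear on it.

Two compounds carry numbers in a functional assay on DU-145 cells (Homo sapiens) for cytotoxicity, read by trypan blue exclusion, with a stated time of 96 h; a higher number here means a weaker inhibitor, a lower number a stronger inhibitor. Compound 1 `COc1ccc(CS(=O)(=O)/C=C/c2c(OC)cc(OCCCC(=O)O)cc2OC)cc1N` gives 25000 nM in this assay. Compound 2 `COC(=O)[C@H](C)Nc1cc(CS(=O)(=O)/C=C/c2c(OC)cc(OC)cc2OC)ccc1OC` gives 750 nM in this assay, the lowest of the two numbers, and its gap to compound 1 lies beyond the scatter. Within the data shown here, no single-change step connects these two, so their values speak only for themselves. Compound 3 `COc1cc(OC)c(/C=C/S(=O)(=O)Cc2ccc(OC)c(NC(C(=O)O)c3ccc(Br)cc3)c2)c(OC)c1` has not yet been measured in this assay. It differs from compound 2 by (4-bromophenyl)(carboxy)methyl in place of 1-(methoxycarbonyl)ethyl on a nitrogen on an aromatic ring. Among the measured compounds shown here, no measured step of the same kind exists, so the size of the move from compound 2 to compound 3 is open; the group that enters is larger and carries a carboxy group. The account expects the number to rise, toward weaker inhibition, partly because compound 1 gives 25000 nM while also bearing a carboxylic acid. The estimate for compound 3 is 3000 nM, with a range from 800 nM to 15000 nM. This corresponds to an expected step of a 4.0-fold higher number from compound 2 to compound 3 (0.60 log units; beyond the scatter).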

Compound 3, half-maximal inhibitory concentration: 300 nM
Beside the measured number, compound 3's estimate is 10-fold (1.00 log units) above it; the whole stated range lies above it.
By their numbers in this assay, from the lowest: compound 3; then compound 2; then compound 1.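

Among these compounds, this is the first single-change step at this place, on a nitrogen on an aromatic ring: in this assay, placing (4-bromophenyl)(carboxy)methyl in place of 1-(methoxycarbonyl)ethyl gives a 2.5-fold lower number from compound 2 to compound 3 (0.40 log units; beyond the scatter) and leaves compound 3 with the lowest number of the three. It shows that this larger group, with its aromatic ring and carboxy group, can stand on this nitrogen without the number rising; compound 1 also carries a carboxy group, but it differs from compound 3 in more than one place and offers no comparison. Nothing measured here explains the step.

As far as these compounds go, the bromine, the aromatic ring and the carboxy group enter together, so their separate shares in the step remain open. Compounds with a chlorine atom in place of the bromine, or a primary amide in place of the carboxy group, would begin to separate them.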